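Swapping methoxy for fluoro on a furan-linked amidine

This account rests on a few compounds, and the source may have more. Where it says the series, first, only, none or still open, it means among the compounds named here.

Measured compounds:
- compound 1, `COc1ccc(-c2ccc(-c3ccc(C(=N)N)o3)o2)cc1`: 860 nM
- compound 2, `N=C(N)c1ccc(-c2ccc(-c3cncc4ccccc34)s2)s1`: 1270 nM
- compound 3, `COc1cc(OC)cc(-c2ccc(-c3ccc(C(=N)N)o3)o2)c1`: 2410 nM

All three were tested in a functional assay on MDA-MB-468 cells (Homo sapiens) for inhibition, read by sulforhodamine B assay, with a stated time of 48 h; on this read-out lower numbers stand for stronger inhibition of growth and higher numbers for weaker inhibition of growth. Compound 1 gives the lowest number of the three. Compound 2 lies close to it, within the usual scatter of this kind of measurement, so the two cannot be ranked against each other. Compound 3 sits clearly higher than compound 1, beyond the scatter, and so inhibits growth less strongly.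

Compound 4, `N=C(N)c1ccc(-c2ccc(-c3ccc(F)cc3)o2)o1`, has not yet been measured. It differs from compound 1 in one place: fluoro in place of methoxy on an aromatic carbon. Among the compounds with values here, no pair of measured compounds shows this same change, so its effect has to be guessed. Within the data shown here, a small substituent on the outer six-membered ring is kept in both cases, and nothing among the measured compounds points to a large shift; the expected step from compound 1 to compound 4 is a 1.4-fold higher number from compound 1 to compound 4 (0.14 log units; within the scatter), that is, no clear change beyond the scatter. Compound 4 is therefore estimated at 1200 nM, with a likely range from 400 nM to 3500 nM.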

Compound 4, concentration for 50% growth inhibition: 1360 nM
For compound 4 the middle estimate is 1.1-fold (0.05 log units) below the measured one; low and high end bracket the measured number.
By their numbers in this assay, from the lowest: compounds 1, 2, 4 and 3 (each within the scatter of the next, the first and the last beyond it).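

In this assay, putting fluoro in place of methoxy on the outer six-membered ring, para to a large group, gives a 1.6-fold higher number from compound 1 to compound 4 (0.20 log units; within the scatter) and so no clear change in growth inhibition. Within the data shown here, this is the first direct reading at this position: the methoxy group, with its oxygen and its carbon, can give way to a single fluorine atom without a shift that stands out from the scatter. Nothing in the data shown explains why these two groups read alike.

The compounds shown place only methoxy and fluoro here, so this one step cannot say how an amine, a carboxylic acid or a longer chain such as butoxy would read at the same position. Going by these compounds, whether the shared core needs any group at this position, or would read the same with plain hydrogen, also stays open.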